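A few compounds are considered here, and "the series" means these few. Any claim that something is new, unique, unknown or untested is made for them only; others in the source may bear on it.

Within the data shown here, compound 2 `Cc1ccccc1NC(=O)c1ccc(Nc2ncc(C)c(-c3ccc(OC(F)(F)F)cc3)n2)cc1` gives 1 nM in an assay on NIH3T3 cells for inhibition of Sonic hedgehog protein (Mus musculus), read by a luciferase reporter, with a stated time of 48 h (a higher number here means a weaker inhibitor, a lower number a stronger inhibitor), the lowest of the two numbers measured so far. Among the measured compounds shown here, the nearest measured neighbour is compound 1 `Cc1ccccc1C(=O)Nc1ccc(Nc2ncc(C)c(-c3ccc(OC(F)(F)F)cc3)n2)cc1`, which in this assay gives 42.1 nM; the only measured step, a 42-fold lower number from compound 1 to compound 2 (1.62 log units; beyond the scatter), concerns the direction of the amide link between the two aromatic parts and not the group on the amide-type nitrogen.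

Compound 3 `Cc1cnc(Nc2ccc(C(=O)NC3CCCCC3)cc2)nc1-c1ccc(OC(F)(F)F)cc1` keeps the amide direction of compound 2 and differs from it by cyclohexyl in place of 2-methylphenyl on an amide-type nitrogen. For the measured compounds named here, no measured step bears on an exchange at this nitrogen, so the expectation rests on the structural change alone. Because compound 2 stands at 1 nM, a modest rise in the number is expected rather than a further fall, a step of about a 4.0-fold higher number from compound 2 to compound 3 (0.60 log units; beyond the scatter). Compound 3 is therefore estimated at 4 nM in this assay, with a range from 0.8 nM to 25 nM.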

Compound 3, half-maximal inhibitory concentration: 2.2 nM
Compound 3: middle estimate off by 1.8-fold (0.26 log units), on the high side, and the stated range covers the measured number.
By their numbers in this assay, from the lowest: compound 2; then compound 3; then compound 1.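

Placing cyclohexyl instead of 2-methylphenyl on the amide-type nitrogen gives only a modest change in this assay (a 2.2-fold higher number from compound 2 to compound 3 (0.34 log units; beyond the scatter)), so among the compounds shown, an aromatic ring on this nitrogen is not needed for a low number. The number also stays well under that of the reversed amide (a 19-fold lower number from compound 1 to compound 3 (1.28 log units; beyond the scatter)), although this step changes both the amide direction and the ring and cannot separate the two. No accompanying measurement offers an explanation for either step.

As far as these compounds go, it remains open how an open chain such as n-hexyl, a small group such as methyl, or a cyclohexyl bearing a carboxylic acid would read on this nitrogen. From the compounds shown here alone, the effect of cyclohexyl on the reversed amide, apart from the amide direction, also remains open.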